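Triazole for Phenyl at the Chain End of a Pyrimidine

The source may hold more compounds than are shown below. What is called first, only, known or untested is meant among the compounds shown, and "the series" means these compounds.

Compound 1 `CCCCNc1nc(N)nc(C)c1CCCN1Cc2ccccc2C1`: 29 nM
Compound 2 `CCCCNc1nc(N)nc(C)c1CCc1ccccc1`: 1190 nM

In an assay on HEK293 cells for agonist activity at Toll-like receptor 8 (Homo sapiens), read by spectrophotometry (a higher number here means that more compound is needed for the effect, a lower number that less compound is needed), compound 2 gives 1190 nM, the highest of the two numbers; compound 1 gives 29 nM, a gap that lies beyond the scatter. Compound 3 `CCCCNc1nc(N)nc(C)c1CCCn1cncn1` differs from compound 2 by (1H-1,2,4-triazol-1-yl)methyl in place of phenyl on a saturated chain carbon, two bonds along the chain from an aromatic carbon. Within the data shown here, no measured pair shows this change, so its size is open. A moderate move toward a lower number in this assay is expected, a 3.0-fold lower number from compound 2 to compound 3 (0.47 log units; beyond the scatter), since compound 1, whose chain ends in a nitrogen-containing ring, gives 29 nM. Compound 3 is estimated at 400 nM, within 100 nM to 2000 nM.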

Compound 3, half-maximal effective concentration: 1050 nM
Compound 3: the middle estimate sits 2.6-fold (0.42 log units) below what was measured; measured number inside the range.
By their numbers in this assay, from the lowest: compound 1; then compounds 3 and 2 (each within the scatter of the next).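

In this assay, the change at this saturated chain carbon gives a 1.1-fold lower number from compound 2 to compound 3 (0.05 log units; within the scatter) and stays within the scatter. At this position, therefore, a five-membered aromatic ring with hetero atoms, reached through its methyl link, reads the same as phenyl, so hetero atoms in an aromatic chain end do not by themselves bring the number down. Nothing available explains this flat step.

On these data alone, what stays open is how a piperidine or a primary amine would read on the same chain. A longer chain ending in phenyl is equally unresolved.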